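Swapping the benzyl halogen on a dithiocarbamate triazole

This account rests on a few compounds, and the source may have more. Where it says the series, first, only, none or still open, it means among the compounds named here.

Compound 1, `O=C1/C(=C/c2ccccc2F)CN(C(=S)SCc2cn(Cc3cccc(Cl)c3)nn2)C/C1=C\c1ccccc1F`, gives > 100000 nM in a functional assay on 4T1 cells (Mus musculus) for cytotoxicity, read by MTT assay, with a stated time of 24 h; on this read-out higher numbers stand for weaker inhibition and lower numbers for stronger inhibition.
Compound 2, `Cc1ccc(/C=C2\CN(Cc3cn(Cc4ccccc4F)nn3)C/C(=C\c3ccc(C)cc3)C2=O)cc1`, gives 18000 nM in this assay.

The value for compound 1 is a limit of the assay and not a number; it sits at the limit of > 100000 nM in this assay, at which 1 of the 2 values shown sits. Compound 1 therefore stands at the weak end of what this assay can report. Going by the values given here, compound 2 shares the central core but differs from compound 1 in several places, so its value shows only that a related compound does register a number in this assay. Compound 3, `O=C1/C(=C/c2ccccc2F)CN(C(=S)SCc2cn(Cc3ccccc3F)nn2)C/C1=C\c1ccccc1F`, differs from compound 1 in one place: 2-fluorophenyl in place of 3-chlorophenyl on a saturated chain carbon bound to an aromatic nitrogen. No measured step of this kind exists among these compounds, so the size of the change is uncertain. Because compound 1 sits at the limit of > 100000 nM in this assay, at which 1 of the 2 values shown sits, the step from compound 1 to compound 3 is expected to be an at least 1.4-fold lower number from compound 1 to compound 3 (0.15 log units; that floor lies within the scatter), a modest gain at most. Compound 3 is thus estimated at 70000 nM, with a range from 15000 nM to 300000 nM.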

Compound 3, half-maximal inhibitory concentration: 30700 nM
Compound 3: the middle estimate sits 2.3-fold (0.36 log units) above what was measured; the measured number falls inside the stated range.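

With the rest of the molecule unchanged, 2-fluorophenyl in place of 3-chlorophenyl on a saturated chain carbon bound to an aromatic nitrogen gives, in this assay, an at least 3.2-fold lower number from compound 1 to compound 3 (0.51 log units; beyond the scatter). Going by these compounds alone, this shows what the earlier compounds could not: a change at this one position is enough to bring a compound from the limit of the read-out to a measured number. The step is only a floor and its full size stays unknown, because compound 1 stands at a limit and not at a number: the limit of > 100000 nM in this assay, at which 1 of the 3 values shown sits.

The halogen and the place it occupies on the ring change together, so the compounds shown cannot separate the two. They also leave open how a 2-chlorobenzyl, a 3-fluorobenzyl or an unsubstituted benzyl group would read at this position.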